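A stereocentre inverted at the cytotoxicity limit

This account rests on a few compounds, and the source may have more. Where it says the series, first, only, none or still open, it means among the compounds named here.

Measured in a functional assay on Vero cells (Chlorocebus sabaeus) for cytotoxicity; on this read-out lower numbers stand for stronger inhibition and higher numbers for weaker inhibition:
- compound 1 `Nc1ncnc2c1ncn2[C@@H]1CC(F)(F)[C@H](CO)O1`: > 100000 nM, a limit
- compound 2 `Nc1ncnc2c1ncn2[C@H]1CC(F)(F)[C@H](CO)O1`: > 100000 nM, a limit
- compound 3 `OC[C@@H]1O[C@H](n2cnc3c(O)ncnc32)CC1(F)F`: > 100000 nM, a limit

Compound 3 gives > 100000 nM in this assay, which is a limit and not a number. Its standing is defined only by the limit of > 100000 nM in this assay, at which 3 of the 3 values shown sit.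

Compound 4 `OC[C@@H]1O[C@@H](n2cnc3c(O)ncnc32)CC1(F)F` departs from compound 3 in configuration alone: the two compounds have the same atoms and bonds and differ only in configuration as drawn: 1 of 2 stereo elements differ; a stereocentre at a saturated ring carbon is drawn S in compound 3 and R in compound 4. Among the measured compounds shown here, the closest precedent is a step that the two limits leave unreadable from compound 1 to compound 2, where a stereocentre at a saturated ring carbon is drawn S in compound 1 and R in compound 2. That pair rests on (the fact that compounds 1 and 2 differ only in the configuration as drawn), so it is the same kind of change, but it gives no size to carry over. The other measured step, a step that the two limits leave unreadable from compound 1 to compound 3, places hydroxy in place of amino on an aromatic carbon and likewise has no readable size. The data therefore contain no measured effect of configuration in this series, and they offer no direction for one.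

Nothing beyond the scatter is expected in this assay, and the expected result is a number no higher from compound 3 to compound 4 (the limit leaves the size open). Compound 4 is estimated at 100000 nM, within an expected range of 50000 nM to 200000 nM, and it will most likely be reported only as a limit.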

Compound 4, half-maximal inhibitory concentration: > 100000 nM
Compound 4: a limit, no number; the forecaster's own chance of this, stated with the estimate: 93%; the middle value sits exactly at the limit.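

In this assay compound 4 gives > 100000 nM, which is a limit and not a number. Among the compounds shown here, no new step can therefore be read, either between compound 3 and compound 4 or between compound 2 and compound 4. The compounds shown leave open whether configuration, or hydroxy in place of amino, shifts this read-out at all, as they show only one boundary: the limit of > 100000 nM in this assay, at which 4 of the 4 values shown sit.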